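The compounds below may be only part of what the source reports. "The series", "measured", "known", "first", "only" and "open" are said of these compounds alone.

Three compounds of the series carry numbers in a physicochemical assay for lipophilicity, using the shake flask method, measured as octanol-water partition, with a stated time of 15 min; on this read-out higher numbers stand for higher lipophilicity and lower numbers for lower lipophilicity. Compound 1 `CCOC(=O)N[C@H](C)c1nc2ccc(F)cc2s1` gives 4.2, compound 2 `CCCOC(=O)N[C@H](C)c1nc2ccc(F)cc2s1` gives 4.56, and compound 3 `C[C@@H](NC(=O)OCC(F)(F)F)c1nc2ccc(F)cc2s1` gives 2.69. Compound 3 stands lowest of the three, with compound 1 nearest and compound 2 furthest. The steps among them are a number 0.36 log units higher from compound 1 to compound 2 (beyond the scatter), a number 1.51 log units lower from compound 1 to compound 3 (beyond the scatter) and a number 1.87 log units lower from compound 2 to compound 3 (beyond the scatter).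

Compound 4 `C[C@@H](NC(=O)OCC(F)(F)C(F)(F)C(F)(F)F)c1nc2ccc(F)cc2s1` has not yet been measured in this assay. It differs from compound 3 in one place: 1,1,2,2,2-pentafluoroethyl in place of fluoro on a saturated chain carbon bound to two fluorine atoms and a saturated chain carbon. Within the data shown here, no measured step swaps one fluorinated group for a larger one, so none bears on this change directly. Two steps are related. Lengthening a chain by one carbon raised the number (a number 0.36 log units higher from compound 1 to compound 2 (beyond the scatter)); the entering pentafluoroethyl brings two carbons. Replacing methyl by trifluoromethyl lowered it by a large amount (a number 1.51 log units lower from compound 1 to compound 3 (beyond the scatter)), but that step exchanged hydrogen for fluorine, whereas the step to compound 4 removes a single fluorine and adds carbons together with fluorine. A rise beyond the scatter is therefore expected, somewhat larger than the one-carbon step, with wide uncertainty.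

For compound 4 the expected number in this assay is 3.6, estimated to lie between 3 and 4.3. This estimate corresponds to an expected step of a number 0.91 log units higher from compound 3 to compound 4 (beyond the scatter).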

Compound 4, partition coefficient: 3.2
Compound 4: middle estimate off by 0.40 log units, on the high side, within the range that was stated.
By their numbers in this assay, from the lowest: compound 3; then compound 4; then compound 1; then compound 2.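

In this assay the carbon bound to two fluorine atoms and a saturated chain carbon tolerates growth with a measurable effect: a number 0.51 log units higher from compound 3 to compound 4 (beyond the scatter) and is, like the one-carbon extension, a modest step beyond the scatter. Adding fluorinated carbons therefore raises the number in this series, but not to the level of the unfluorinated chains, as compound 4 at 3.2 remains under compound 1 at 4.2 and the larger 1,1,2,2,2-pentafluoroethyl group does not recover the earlier drop. Nothing measured here bears on why this exchange moves the number upward.

The compounds shown leave open whether a longer perfluorinated chain, such as nonafluorobutyl in place of the 1,1,2,2,2-pentafluoroethyl of compound 4, would continue the rise, and where a difluoromethyl group in place of the trifluoromethyl of compound 3 would fall. Going by these compounds, how a hydroxyl or an amine on this chain would read in this assay also remains open, as does whether the same step holds on a different core.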